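Ring size at the amine of a nitroquinolinol series

A few compounds are considered here, and "the series" means these few. Any claim that something is new, unique, unknown or untested is made for them only; others in the source may bear on it.

Compound 1: `Cc1cc(C)cc(-c2c(O)nc3cc(Cl)c([N+](=O)[O-])cc3c2OCCC2CCCCN2C)c1` — 32 nM
Compound 2: `Cc1cc(C)cc(-c2c(O)nc3cc(Cl)c([N+](=O)[O-])cc3c2OCC[C@@H]2CCCCN2C)c1` — 20 nM
Compound 3: `Cc1cc(C)cc(-c2c(O)nc3cc(Cl)c([N+](=O)[O-])cc3c2OCC[C@@H]2CCCCN2)c1` — 10 nM

Three compounds share the core and differ only in the amine ring at the end of the ethoxy chain. In an assay on cell membranes for binding affinity to Gonadotropin-releasing hormone receptor (Rattus norvegicus), read by radioligand binding (on this read-out lower numbers stand for stronger inhibition and higher numbers for weaker inhibition), compound 3 gives the lowest of the three numbers; the steps that reach it are a 2.0-fold lower number from compound 2 to compound 3 (0.30 log units; within the scatter) and a 3.2-fold lower number from compound 1 to compound 3 (0.51 log units; beyond the scatter). The step of a 1.6-fold lower number from compound 1 to compound 2 (0.20 log units; within the scatter) is tied to the fact that one of compounds 1 and 2 is drawn with a defined configuration and the other without, at the place where they differ, and the step of a 2.0-fold lower number from compound 2 to compound 3 (0.30 log units; within the scatter) removes the methyl from the ring nitrogen.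

Compound 4, `Cc1cc(C)cc(-c2c(O)nc3cc(Cl)c([N+](=O)[O-])cc3c2OCCC2CCCCCN2)c1`, is not yet measured. It differs from compound 3 by azepan-2-yl in place of piperidin-2-yl on a saturated chain carbon, two bonds along the chain from an oxygen on an aromatic ring. Going by the values given here, none of the measured steps changes ring size, so none of them speaks directly to this change; the closest analogy is the step from compound 1 to compound 2, where the presence or absence of a drawn configuration at the ring carbon gave only a 1.6-fold lower number from compound 1 to compound 2 (0.20 log units; within the scatter), and compound 4 again carries no drawn configuration at that carbon. No step beyond the scatter is therefore expected in this assay , in either direction. Compound 4 is expected to give about 15 nM (range 5 nM to 45 nM), which would mean an estimated step of a 1.5-fold higher number from compound 3 to compound 4 (0.18 log units; within the scatter).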

Compound 4, half-maximal inhibitory concentration: 36 nM
The estimate for compound 4 lay 2.4-fold (0.38 log units) below the measured number; the measured number falls inside the stated range.
By their numbers in this assay, from the lowest: compounds 3, 2, 1 and 4 (each within the scatter of the next, the first and the last beyond it).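

Widening the amine ring from piperidin-2-yl to azepan-2-yl on the ethoxy chain gives, in this assay, a 3.6-fold higher number from compound 3 to compound 4 (0.56 log units; beyond the scatter), the first view of ring size at this position and a step beyond the scatter. Measured against the 1-methylpiperidin-2-yl compounds, the azepan-2-yl ring stands level: the steps are a 1.8-fold higher number from compound 2 to compound 4 (0.26 log units; within the scatter) and a 1.1-fold higher number from compound 1 to compound 4 (0.05 log units; within the scatter), so the seven-membered ring with an unsubstituted nitrogen cannot be told apart from either of them. Going by these compounds alone, the step from the six-membered ring is not a clean reading of ring size alone, since compound 3 is drawn with a defined stereocentre and compound 4 without one, and the only measured step of that kind, a 1.6-fold lower number from compound 1 to compound 2 (0.20 log units; within the scatter), stayed small and rests on a single pair: the fact that one of compounds 1 and 2 is drawn with a defined configuration and the other without, at the place where they differ.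

The compounds shown leave open how a single configuration of the azepan-2-yl compound would compare with compound 3, and whether a 1-methylazepan-2-yl group would follow the piperidine pair. They also leave open where a smaller pyrrolidin-2-yl ring on the same chain would fall.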